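Removing the Methyl from a Pyrazole with No Response

The compounds below may be only part of what the source reports. "The series", "measured", "known", "first", "only" and "open" are said of these compounds alone.

Measured so far:
Compound 1 `Cn1cccc1-c1ccccc1NCC1=NCCN1` gives 32% in a functional assay with Alpha-1D adrenergic receptor (Homo sapiens) as the target, read by calcium flux; a lower number here means a smaller maximal response, a higher number a larger maximal response.
Compound 2 `Cn1cc(-c2ccccc2NCC2=NCCN2)cn1` gives 0% in this assay.

Compound 2 stands at the bottom of these two numbers, with no response at all. Within the data shown here, its nearest neighbour is compound 1, and the single change between them, a 1-methyl-1H-pyrazol-4-yl in place of a 1-methyl-1H-pyrrol-2-yl on an aromatic carbon, brought a number 32 percentage points lower from compound 1 to compound 2 (beyond the scatter).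

Compound 3 `c1ccc(-c2cn[nH]c2)c(NCC2=NCCN2)c1` keeps the whole frame of compound 2 and changes one thing:

hydrogen in place of methyl on an aromatic nitrogen

Among the measured compounds shown here, no measured step bears directly on this change. For the measured compounds named here, the only step seen, the one from compound 1 to compound 2, swaps one five-membered ring for another rather than removing a methyl from an aromatic nitrogen, so it says nothing about what this smaller change does. With compound 2 already at zero, the number can only stay or rise, and a small change is expected to move it little. The step from compound 2 to compound 3 is therefore estimated as a number 5 percentage points higher from compound 2 to compound 3 (within the scatter), within the usual scatter. Compound 3 is expected to give about 5%, somewhere between 0% and 20%.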

Compound 3, largest response reached (reported as maximal response), in percent of the reference or control that the assay uses: 62%
Compound 3: middle estimate off by 57 percentage points, on the low side; measured number above the stated range.
By their numbers in this assay, from the lowest: compound 2; then compound 1; then compound 3.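

Hydrogen in place of methyl on the aromatic nitrogen gives a number 62 percentage points higher from compound 2 to compound 3 (beyond the scatter) in this assay and turns the lowest number of the three into the highest. Among these compounds, the earlier step showed only that exchanging one five-membered ring for another could lower the number, whereas this one shows that the single methyl on this nitrogen can separate no response from a clear one. The 1H-pyrazol-4-yl group also gives a number 30 percentage points higher from compound 1 to compound 3 (beyond the scatter) when it takes the place of 1-methyl-1H-pyrrol-2-yl, so among these compounds a pyrazole ring does not by itself go with a zero response, and only the methylated form does.

Nothing shown here explains why so small a change moves the number this far.

The compounds shown leave open whether any group on this nitrogen would bring the response down, or only methyl, since an ethyl group or a longer chain in the same place would test this. They also leave open whether a free ring nitrogen gives the same gain in another ring, such as an imidazole or a triazole.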